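Cytotoxicity of a new bis-arylidene cyclohexanone analogue

The source may report more compounds than this note shows. Statements on the series, on what has been measured and on what is new or still open speak of the compounds shown alone.

The measured compounds:
compound 1, `COc1cccc(/C=C2\CCC/C(=C\c3ccccc3Cl)C2=O)c1OC`, 44200 nM
compound 2, `COc1cccc(/C=C2\CCC/C(=C\c3ccc(Cl)cc3)C2=O)c1OC`, 18600 nM
compound 3, `COc1cccc(/C=C2\CCC/C(=C\c3ccc(Cl)c(Cl)c3)C2=O)c1OC`, 25500 nM

Among the compounds with values here, in an ADME assay on NHDF cells (Homo sapiens) for cytotoxicity, read by MTT assay, with a stated time of 72 h (on this read-out lower numbers stand for stronger inhibition and higher numbers for weaker inhibition), compound 2 gives the lowest of the three numbers, though its gap to compound 3 lies within the scatter (a 1.4-fold higher number from compound 2 to compound 3 (0.14 log units; within the scatter)); only the step of a 2.4-fold lower number from compound 1 to compound 2 (0.38 log units; beyond the scatter) is larger, and the step of a 1.7-fold lower number from compound 1 to compound 3 (0.24 log units; within the scatter) stays within the scatter. Compound 4, `COc1cc(/C=C2\CCC/C(=C\c3cccc(OC)c3OC)C2=O)ccc1O`, differs from compound 2 in one place: 4-hydroxy-3-methoxyphenyl in place of 4-chlorophenyl on a double-bonded chain carbon bound to a double-bonded ring carbon. Within the data shown here, none of the measured steps bears directly on this change; all three concern the number or position of chloro substituents on the phenyl ring, and none introduces a hydroxy or methoxy group there. Those steps were modest or within the scatter, so nothing in the data points to a large shift in either direction for this assay. The account therefore expects no step beyond the scatter, with a wide margin of uncertainty. Compound 4 is estimated at 25000 nM, within 8000 nM to 80000 nM, which means an expected step of a 1.3-fold higher number from compound 2 to compound 4 (0.13 log units; within the scatter).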

Compound 4, half-maximal inhibitory concentration: 14300 nM
Beside the measured number, compound 4's estimate is 1.7-fold (0.24 log units) above it, and the stated range covers the measured number.
By their numbers in this assay, from the lowest: compounds 4, 2, 3 and 1 (each within the scatter of the next, the first and the last beyond it).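

In this assay, 4-hydroxy-3-methoxyphenyl on a double-bonded chain carbon bound to a double-bonded ring carbon shows that this ring needs no chloro substituent to stay level with the chlorinated compounds 2 and 3: the result is a 1.3-fold lower number from compound 2 to compound 4 (0.11 log units; within the scatter) and a 1.8-fold lower number from compound 3 to compound 4 (0.25 log units; within the scatter). Only the third comparison passes the scatter, a 3.1-fold lower number from compound 1 to compound 4 (0.49 log units; beyond the scatter), so the replaced group matters here only against the 2-chlorophenyl compound. No evidence at hand accounts for these steps.

The compounds shown leave open whether the hydroxy or the methoxy of the new ring could stand alone at this place with the same reading. They also leave open how an amine or a carboxylic acid on this ring would read in this assay.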